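Exposure of an indole carboxamide pair after ring-nitrogen swap

A few compounds are considered here, and "the series" means these few. Any claim that something is new, unique, unknown or untested is made for them only; others in the source may bear on it.

Three indole carboxamides have been measured in an ADME assay on the whole organism (plasma, strain Sprague-Dawley) for pharmacokinetics, with Rattus norvegicus as the target, with stated times of 6 h and 30 min, at a dose of 10 mg/kg by the oral route; a higher number here means more compound in the circulation at the dose given, a lower number less compound in the circulation. Compound 1 `CC(C)(C)S(=O)(=O)Nc1ccc(-c2c(C(N)=O)c3cc(F)c(OC(F)F)cc3n2C2CCCCC2)c(F)c1` gives 1720 ng.h/mL in this assay. Compound 2 `CC(C)(C)S(=O)(=O)Nc1ccc(-c2c(C(N)=O)c3cc(F)c(OC(F)F)cc3n2-c2ccccc2)c(F)c1` gives 4360 ng.h/mL in this assay. The step between them, (phenyl in place of cyclohexyl on an aromatic nitrogen), makes a 2.5-fold higher number from compound 1 to compound 2 (0.40 log units; beyond the scatter). Compound 3 `Cc1cc2c(cc1F)c(C(N)=O)c(-c1ccc(NS(=O)(=O)C(C)(C)C)cc1)n2C1CCCCC1` gives 333 ng.h/mL in this assay, the lowest of the three numbers and beyond the scatter from both others. The difference between the core of compound 3 and the core of compound 1 is not broken down here.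

Compound 4 `Cc1cc2c(cc1F)c(C(N)=O)c(-c1ccc(NS(=O)(=O)C(C)(C)C)cc1)n2-c1ccccc1` has not yet been measured in this assay. It differs from compound 3 by phenyl in place of cyclohexyl on an aromatic nitrogen, the same change that separates compound 2 from compound 1, made at the same place. It is therefore expected that compound 4 will lie above compound 3 by a step of about a 2.5-fold higher number from compound 3 to compound 4 (0.40 log units; beyond the scatter), resting on the earlier step of a 2.5-fold higher number from compound 1 to compound 2 (0.40 log units; beyond the scatter) and on the value of compound 3 of 333 ng.h/mL. Whether the step carries over from the core of compound 1 to the core of compound 3 is not shown by any measured pair, so the range is kept wide. For compound 4 the estimate in this assay is 830 ng.h/mL, with a lower end of 300 ng.h/mL and an upper end of 2500 ng.h/mL.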

Compound 4, area under the concentration-time curve: 7140 ng.h/mL
Compound 4: middle estimate off by 8.6-fold (0.93 log units), on the low side; measured number outside the range, above it.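

In this assay, phenyl in place of cyclohexyl on the aromatic nitrogen raises the number again, with a 21-fold higher number from compound 3 to compound 4 (1.33 log units; beyond the scatter), so the direction of the change is the same on both cores while its size is not: the same change on two cores in this assay, a 2.5-fold higher number (0.40 log units; beyond the scatter) from compound 1 to compound 2 and a 21-fold higher number (1.33 log units; beyond the scatter) from compound 3 to compound 4, 8.5-fold (0.93 log units) apart, beyond the scatter of two such steps. For this series, the step measured on the core of compound 1 therefore gave the direction of the change on the core of compound 3, but it could not be carried over as a fixed size. For the compounds shown here, with only two pairs, this shows that the size of the step depends on the core in these compounds, but it does not show how the change would behave on a third core, nor does it give any reason for the gap between the two steps.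

The compounds shown leave open which of the differences between the two cores goes with the larger step, since those cores differ in more than one place and each could contribute to it. They also leave open how other groups on the aromatic nitrogen, such as a pyridine ring, a short alkyl chain or a chain ending in an amine, would compare with phenyl and cyclohexyl on either core.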